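This account rests on a few compounds, and the source may have more. Where it says the series, first, only, none or still open, it means among the compounds named here.

In an ADME assay on S9 fraction from intestine (Homo sapiens) for metabolic stability, read by LC-MS, with a stated time of 60 min, tested at 10 uM (a higher number here means that the compound lasts longer, a lower number that the compound disappears faster), compound 1 (`CCOC(=O)[C@H](F)ON1C(=O)N2C[C@H]1C(C)=C[C@H]2C(N)=O`) gives 0.115 h as its half-life, the lower of the two numbers in hand. Compound 2 (`CC1=C[C@@H](C(N)=O)N2C[C@@H]1N(O[C@@H](F)C(=O)OC(C)C)C2=O`) gives 0.6 h in the same test. Going by the values given here, the only measured step is a 5.2-fold higher number from compound 1 to compound 2 (0.72 log units; beyond the scatter) and comes from methyl in place of hydrogen on a saturated chain carbon bound to an oxygen next to a carbonyl group and a saturated chain carbon.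

Compound 3 (`CCOC(=O)[C@@H](F)ON1C(=O)N2C[C@H]1C(C)=C[C@H]2C(N)=O`) is a different kind of case: the two compounds have the same atoms and bonds and differ only in configuration as drawn: 1 of 3 stereo elements differ; a stereocentre at a saturated chain carbon is drawn S in compound 1 and R in compound 3 and no group leaves or enters. The measured step adds a group and leaves the configuration as drawn unchanged, so it bears on compound 3 only indirectly. It shows that one small change can move the number beyond the scatter in this pair. Among the compounds with values here, no pair differing only in configuration has been measured, so the data give neither the size nor the direction of such a change.

The expected result in this assay is a small shift, a 1.2-fold higher number from compound 1 to compound 3 (0.09 log units; within the scatter) with little confidence in its direction.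

Compound 3 is estimated at 0.14 h with an expected range from 0.05 h to 0.5 h for now.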

Compound 3, half-life: 0.583 h
Estimate against measurement, compound 3: 4.2-fold (0.62 log units) below, and the stated range ends below it.
By their numbers in this assay, from the lowest: compound 1; then compounds 3 and 2 (each within the scatter of the next).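

In this assay, configuration at this saturated chain carbon matters on its own, with no group leaving or entering: a 5.1-fold higher number from compound 1 to compound 3 (0.70 log units; beyond the scatter). The change in the number can be assigned to this one stereocentre because nothing else separates the pair: the fact that compounds 1 and 3 differ only in the configuration as drawn. The earlier pair showed only that adding a methyl at a different carbon can move the number, a 5.2-fold higher number from compound 1 to compound 2 (0.72 log units; beyond the scatter), and the new step, also beyond the scatter and in the same direction, shows that a change of drawn configuration alone can do so too, at least on the core of compound 1 with its ethyl ester.

The compounds shown leave open whether the same change of configuration would move the number in the same direction when carried out on compound 2, and so whether the methyl step and the configuration step would add together or overlap. They also leave open how the configuration at this carbon would read with a carboxylic acid or a primary amide in place of the ester, or with a longer chain on the ester oxygen.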